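The compounds below may be only part of what the source reports. "The series", "measured", "known", "first", "only" and "open" are said of these compounds alone.

Compound 3 `CC(C)(C)c1ccc(NC(=O)N2CCCN(C(=O)CCC3CCCC3)CC2)cc1` sits at the lowest of the three numbers recorded in an in vitro ADME assay on microsomes from liver (Homo sapiens) for metabolic stability, read by LC-MS (on this read-out lower numbers stand for a shorter-lived compound and higher numbers for a longer-lived compound), where compound 3 gives 0.05 h. Its nearest neighbour is compound 1 `CCc1ccc(NC(=O)N2CCCN(C(=O)CCC3CCCC3)CC2)cc1`, for which this assay gives 0.0833 h; the step of a 1.7-fold lower number from compound 1 to compound 3 (0.22 log units; within the scatter) stays within the scatter. Further away is compound 2 `CC(C)c1ccc(NC(=O)N2CCCN(C(=O)CCC3CCCC3)CC2)cc1`, which in this assay gives 0.117 h; the step of a 2.3-fold lower number from compound 2 to compound 3 (0.37 log units; beyond the scatter) is a modest one beyond the scatter, while a 1.4-fold higher number from compound 1 to compound 2 (0.15 log units; within the scatter) again stays within it.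

Compound 4 `CC(C)(C)c1ccc(NC(=O)N2CCCN(C(=O)C3CCOCC3)CC2)cc1` differs from compound 3 at the other end of the shared core: oxan-4-yl in place of 2-cyclopentylethyl on a carbonyl carbon. None of the three measured steps touches this position; each of them alters only the group on the aromatic ring, and every one of the three compounds carries the same (2-cyclopentylethyl)carbonyl. Among the measured compounds shown here, the data therefore give no measured step that bears on the change to compound 4, and only the narrow spread of all three values, two of them within the scatter of compound 3, offers a footing.

On that footing the account expects compound 4 to remain close to compound 3, with the step of a 1.6-fold higher number from compound 3 to compound 4 (0.20 log units; within the scatter) estimated as not beyond the scatter. The half-life of compound 4 is thus estimated at 0.08 h, within a range from 0.03 h to 0.25 h.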

Compound 4, half-life: 0.183 h
The estimate for compound 4 lay 2.3-fold (0.36 log units) below the measured number; measured number inside the range.
By their numbers in this assay, from the lowest: compounds 3, 1, 2 and 4 (each within the scatter of the next, the first and the last beyond it).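

Among the compounds shown here, at the carbonyl end of the shared core, the first reading in this assay comes with a 3.7-fold higher number from compound 3 to compound 4 (0.56 log units; beyond the scatter), so this position can move the half-life beyond the scatter, whereas the earlier steps reported only on the group on an aromatic carbon. The change replaces 2-cyclopentylethyl, with its five-membered carbon ring and seven carbon atoms, by oxan-4-yl, with its six-membered ring, one oxygen and one hydrogen-bond acceptor, so ring size, chain and hetero atom all differ in this single step and cannot be told apart. Nothing available accounts for the longer half-life of compound 4.

The compounds shown leave open whether the oxygen itself matters, which cyclohexyl on the same carbonyl carbon would address, and whether an amine in that ring, such as piperidin-4-yl, would read like oxan-4-yl. They also leave open whether oxan-4-yl would give a similar step with the ethyl of compound 1 or the isopropyl of compound 2 in place of tert-butyl on the aromatic carbon.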